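The compounds below may be only part of what the source reports. "The series", "measured", "known", "first", "only" and "open" are said of these compounds alone.

In an ADME assay on HPLF cells (Homo sapiens) for cytotoxicity, with a stated time of 24 h (on this read-out lower numbers stand for higher toxicity in this test and higher numbers for lower toxicity in this test), compound 1 `COc1cc(/C=C2\CCC/C(=C\c3ccccc3[N+](=O)[O-])C2=O)cc(OC)c1OC` gives 79000 nM, the higher of the two numerical values in the series. Compound 2 `O=C1/C(=C/c2ccccc2)CCC/C1=C\c1cccc([N+](=O)[O-])c1` gives 18000 nM. Compound 3 `CN(C)c1ccc(/C=C2\CCC/C(=C\c3cccc([N+](=O)[O-])c3)C2=O)cc1` is recorded only as a limit of the assay at > 400000 nM.

Compound 4 `COc1cc(/C=C2\CCC/C(=C\c3cccc([N+](=O)[O-])c3)C2=O)cc(OC)c1OC` differs from compound 1 by 3-nitrophenyl in place of 2-nitrophenyl on a double-bonded chain carbon bound to a double-bonded ring carbon. Among the compounds with values here, no measured step covers this change. Within the data shown here, the only one available, an at least 22-fold higher number from compound 2 to compound 3 (1.34 log units; beyond the scatter), is a different change and shows only that values can differ widely between compounds carrying 3-nitrophenyl. A step of a 1.3-fold lower number from compound 1 to compound 4 (0.12 log units; within the scatter) is expected, which stays within the scatter. For compound 4 the estimate is 60000 nM, with a range from 15000 nM to 250000 nM.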

Compound 4, half-maximal cytotoxic concentration: > 400000 nM
Compound 4 gave a limit, no number; the forecaster's own chance of this, stated with the estimate: 10%; middle value at least 6.6-fold (0.82 log units) away from the limit.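

Within the data shown here, on a double-bonded chain carbon bound to a double-bonded ring carbon, 3-nitrophenyl in place of 2-nitrophenyl gives the first step at this position in this assay: an at least 5.0-fold higher number from compound 1 to compound 4 (0.70 log units; beyond the scatter). The two groups hold the same atoms, joined differently, and this alone separates compound 1 from compound 4. The value of compound 4 is a limit, so the step has no upper size: the limit of > 400000 nM in this assay, at which 2 of the 4 values shown sit.

On these data alone, compound 2 and compound 3 have no 2-nitrophenyl partner, so it remains open whether the step holds with other groups on the core. As far as these compounds go, an amine or a carboxylic acid in place of the nitro group also remains open.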